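A few compounds are considered here, and "the series" means these few. Any claim that something is new, unique, unknown or untested is made for them only; others in the source may bear on it.

In a functional assay on PC-3 cells (Homo sapiens) for antiproliferative activity, read by MTT assay, with a stated time of 48 h (a higher number here means a weaker inhibitor, a lower number a stronger inhibitor), compound 3 (`COc1ccc(/C=C/C(=O)c2cc(OC)c(OC)c(OC)c2)cc1OCCCC(=O)NCCCCN(CCCN)CCCCN`) stands at 60600 nM and so lies within the scatter of compound 1 (`COc1cc(C(=O)/C=C/c2ccc(OCCCC(=O)NCCCCN(CCCN)CCCCN)cc2)cc(OC)c1OC`) at 55400 nM in the same read-out. Compound 2 (`COc1cc(C(=O)/C=C/c2ccc(OCCCC(=O)NCCCNCCCCN)cc2)cc(OC)c1OC`) is recorded as > 100000 nM which is a limit of the assay and not a number. Compound 4 (`COc1ccc(/C=C/C(=O)c2cc(OC)c(OC)c(OC)c2)cc1OCCCC(=O)NCCCCNCCCN`) differs from compound 3 by one change (hydrogen in place of 4-aminobutyl on an amine nitrogen), hydrogen in place of 4-aminobutyl on an amine nitrogen. Among the compounds with values here, the only measured step that bears on this is a similar loss of an aminoalkyl arm (an at least 1.8-fold higher number from compound 1 to compound 2 (0.25 log units; that floor lies within the scatter)). A higher number of about that size is therefore expected in this assay for compound 4, although that floor does not itself go beyond the scatter. The expected change is a single step (a 1.8-fold higher number from compound 3 to compound 4 (0.26 log units; within the scatter)). Compound 4 is estimated at 110000 nM with a range from 60000 nM to 250000 nM and is expected perhaps to give only a limit.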

Compound 4, half-maximal inhibitory concentration: 51000 nM
For compound 4 the middle estimate is 2.2-fold (0.33 log units) above the measured one, and the stated range ends above it.
By their numbers in this assay, from the lowest: compounds 4, 1 and 3 (each within the scatter of the next). At a limit, above all of these: compound 2.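

In this assay, within the data shown here, the loss of the 4-aminobutyl arm gives a 1.2-fold lower number from compound 3 to compound 4 (0.07 log units; within the scatter) and is the first step here with a number at both ends. On this amine nitrogen, hydrogen can therefore replace that arm with no change beyond the scatter, whereas the earlier step gave only a floor. Compound 2 remains a limit of the assay and not a number: the limit of > 100000 nM in this assay, at which 1 of the 4 values shown sits.

Still open, from the compounds shown here alone, is whether a methyl or an acetyl on this amine nitrogen would shift the number beyond the scatter. The same holds for a longer chain in place of the 3-aminopropyl arm.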